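Adding a Nitro Group to the Phenyl Ring of Compound 2

The source may hold more compounds than are shown below. What is called first, only, known or untested is meant among the compounds shown, and "the series" means these compounds.

Measured compounds:
compound 1, `CN1C(=O)N(C)C2C1NC(=S)N2/N=C/C=C/c1ccccc1`, > 100000 nM
compound 2, `CCN1C(=O)N(CC)C2C1NC(=O)N2/N=C/C=C/c1ccccc1`, 83200 nM

For the measured compounds named here, in a functional assay on MCF7 cells (Homo sapiens) for inhibition, read by MTT assay, with a stated time of 72 h (a lower number here means a stronger inhibitor, a higher number a weaker inhibitor), compound 2 gives 83200 nM, the only number among the two values shown. Compound 1 reaches > 100000 nM in this assay, which is a limit of the assay rather than a number. One of the two values thus sits at the limit of > 100000 nM in this assay, at which 1 of the 2 values shown sits. Compound 2 therefore stands as the sole reference point for any step.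

Compound 3, `CCN1C(=O)N(CC)C2C1NC(=O)N2/N=C/C=C/c1ccccc1[N+](=O)[O-]`, differs from compound 2 by nitro in place of hydrogen on an aromatic carbon. Going by the values given here, no step between two measured compounds is available to calibrate this change, so the expectation for compound 3 rests on compound 2 alone. A change of this kind, a nitro group entering an aromatic carbon of the phenyl ring, is expected to move the value by no more than the usual scatter, in either direction, with a real chance that the assay again reports only a limit. Compound 3 is therefore estimated at 60000 nM, with a range from 15000 nM to 200000 nM. That estimate means a step of a 1.4-fold lower number from compound 2 to compound 3 (0.14 log units; within the scatter), expected to lie within the scatter.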

Compound 3, half-maximal inhibitory concentration: 88000 nM
The estimate for compound 3 lay 1.5-fold (0.17 log units) below the measured number, within the range that was stated.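

For the compounds shown here, the change from phenyl to 2-nitrophenyl supplies the only step that can be read in this assay, and it reads a 1.1-fold higher number from compound 2 to compound 3 (0.02 log units; within the scatter). Until now compound 2 stood alone as a reference point, whereas this step shows that the aromatic carbon ortho to a large group can take nitro in place of hydrogen with no difference that can be told from the scatter, and that compound 3 still gives a number, 88000 nM, rather than a limit. Compound 1 remains the one compound reported only as a limit of the assay: the limit of > 100000 nM in this assay, at which 1 of the 3 values shown sits.

From the compounds shown here alone, what an amine or a carboxylic acid would do on this same aromatic carbon stays open, as does the outcome of placing nitro on another carbon of the phenyl ring. It also stays open whether any change on this ring can move the number beyond the scatter, as the one step shown does not.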